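The source may hold more compounds than are shown below. What is called first, only, known or untested is meant among the compounds shown, and "the series" means these compounds.

Two analogues of the shared core are measured in a functional assay on SF-268 cells (Homo sapiens) for inhibition, read by sulforhodamine B assay, with a stated time of 48 h; on this read-out higher numbers stand for weaker inhibition of growth and lower numbers for stronger inhibition of growth. Compound 1 `O=C(Nc1cccc(-n2cc(-c3ccncc3)c(-c3ccc(Cl)c(O)c3)n2)c1)Nc1ccc(Cl)c(Cl)c1` gives 1490 nM, and compound 2 `O=C(Nc1cccc(-n2cc(-c3ccncc3)c(-c3ccc(Cl)c(O)c3)n2)c1)Nc1cc(C(F)(F)F)cc(C(F)(F)F)c1` gives 846 nM. Of these two numbers compound 1 stands at the top, yet the gap to compound 2 lies within the scatter, so the pair shows no real difference. Compound 3 `O=C(Nc1cccc(-n2cc(-c3ccncc3)c(-c3ccc(Cl)c(O)c3)n2)c1)Nc1ccc(Cl)c(C(F)(F)F)c1` is not yet measured; it differs from compound 1 by trifluoromethyl in place of chloro on an aromatic carbon. Among the measured compounds shown here, with only two values and no step between measured compounds to lean on, the step of a 1.4-fold lower number from compound 1 to compound 3 (0.13 log units; within the scatter) is expected to stay within the scatter. For compound 3 the estimate is 1100 nM, between 500 nM and 2500 nM.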

Compound 3, concentration for 50% growth inhibition: 1060 nM
The estimate for compound 3 lay 1.0-fold (0.02 log units) above the measured number; low and high end bracket the measured number.
By their numbers in this assay, from the lowest: compounds 2, 3 and 1 (each within the scatter of the next).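

Trifluoromethyl in place of chloro on this aromatic carbon, ortho to a chloro group, gives a 1.4-fold lower number from compound 1 to compound 3 (0.15 log units; within the scatter) in this assay. This first single-place step in the series shows that four heavy atoms can stand here in place of one without a change beyond the scatter. Nothing at hand gives a reason for this result.

Open, as far as these compounds go, is whether an amine, a methoxy group or a carboxylic acid on this carbon would move the number beyond the scatter. Also open, from the compounds shown here alone, is what hydrogen in place of the remaining chloro group would do.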